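Adding an amino group to the amide of compound 2

A few compounds are considered here, and "the series" means these few. Any claim that something is new, unique, unknown or untested is made for them only; others in the source may bear on it.

Compound 2 `CN(CCC(N)=O)C[C@H]1O[C@@H](n2cnc3c(N)ncnc32)[C@H](O)[C@@H]1O` gives 7000 nM in an assay on isolated protein for inhibition of S-adenosylmethionine decarboxylase proenzyme (Homo sapiens); a lower number here means a stronger inhibitor, a higher number a weaker inhibitor. Compound 3 `CCc1nc2c(N)ncnc2n1[C@@H]1O[C@H](CN(C)CCC(N)=O)[C@@H](O)[C@H]1O` gives 4000 nM, a difference within the usual scatter, while compound 1 `Cc1nc2c(N)ncnc2n1[C@@H]1O[C@H](C[S+](C)C)[C@@H](O)[C@H]1O` gives 3000 nM, a gap beyond it. Going by the values given here, the only measured single-change step, a 1.8-fold lower number from compound 2 to compound 3 (0.24 log units; within the scatter), alters an aromatic carbon and so tells little about the amide end of the side chain. Compound 4 `CN(CCC(=O)NN)C[C@H]1O[C@@H](n2cnc3c(N)ncnc32)[C@H](O)[C@@H]1O` differs from compound 2 by amino in place of hydrogen on an amide-type nitrogen. Among the compounds with values here, no measured step touches this amide-type nitrogen, so nothing seen here supports a shift beyond the scatter in either direction. The expected step is therefore no change at the digits printed from compound 2 to compound 4 (within the scatter). Compound 4 is estimated at 7000 nM, with a range from 2500 nM to 20000 nM.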

Compound 4, half-maximal inhibitory concentration: 1500 nM
The estimate for compound 4 lay 4.7-fold (0.67 log units) above the measured number; the measured number lies below the stated range.
By their numbers in this assay, from the lowest: compounds 4, 1, 3 and 2 (each within the scatter of the next, the first and the last beyond it).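

In this assay the amide-type nitrogen turns out to be a place where a small change counts: amino in place of hydrogen gives a 4.7-fold lower number from compound 2 to compound 4 (0.67 log units; beyond the scatter) and so moves the number further than the scatter, unlike the earlier step on the aromatic carbon. The amide end of the side chain therefore matters in this series. Nothing available explains why this step lowers the number.

As far as these compounds go, it remains open whether methyl or hydroxy on this nitrogen would act like amino, or whether a carboxylic acid could replace the amide. From the compounds shown here alone, it is also open whether amino would give a similar step on compound 3.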